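Swapping the trichloroethyl carbamate for an ethyl carbamate

The source may hold more compounds than are shown below. What is called first, only, known or untested is meant among the compounds shown, and "the series" means these compounds.

Measured so far in an assay for inhibition of serine/threonine-protein kinase PAK 4 (Homo sapiens), read by FRET and Z'-LYTE, with a stated time of 60 min, tested at 0.5 uM, in the presence of a further agent that is not named here; on this read-out higher numbers stand for a stronger effect at the one concentration tested and lower numbers for a weaker effect:
- compound 1 `COC(=O)N1CCN(C(=O)c2nc(Nc3cc(C4CC4)[nH]n3)c3cc(Cl)ccc3n2)C[C@H]1C` gives 73.9%
- compound 2 `C[C@@H]1CN(C(=O)c2nc(Nc3cc(C4CC4)[nH]n3)c3cc(Cl)ccc3n2)CCN1C(=O)OCC(Cl)(Cl)Cl` gives -1.5%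

Compound 2 stands lowest of the two numbers measured; its nearest neighbour is compound 1, which sits far above it. The two differ in one place: the carbamate of compound 1 carries hydrogen on a saturated chain carbon bound to an oxygen next to a carbonyl group, while compound 2 carries trichloromethyl there, and that single exchange gave a number 75.4 percentage points lower from compound 1 to compound 2 (beyond the scatter).

Compound 3 `CCOC(=O)N1CCN(C(=O)c2nc(Nc3cc(C4CC4)[nH]n3)c3cc(Cl)ccc3n2)C[C@H]1C` is the unmeasured ethyl carbamate. Its difference from compound 2 is methyl in place of trichloromethyl on a saturated chain carbon bound to an oxygen next to a carbonyl group. Going by the values given here, the only step that bears on it is the one from compound 1 to compound 2, which was large and downward when trichloromethyl was introduced; removing trichloromethyl again, even though methyl rather than hydrogen takes its place, should therefore undo most of that loss. A large upward step is expected, a number 66.5 percentage points higher from compound 2 to compound 3 (beyond the scatter). Compound 3 is estimated at 65%, with a range from 40% to 85%.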

Compound 3, a percentage reported as inhibition, at one concentration (the size of the read-out at that concentration, not a potency): 42.4%
The estimate for compound 3 lay 22.6 percentage points above the measured number, within the range that was stated.
By their numbers in this assay, from the lowest: compound 2; then compound 3; then compound 1.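

In this assay the change from trichloromethyl to methyl on the saturated chain carbon bound to an oxygen next to a carbonyl group gives a number 43.9 percentage points higher from compound 2 to compound 3 (beyond the scatter) and so recovers much of the effect, which shows that the near-total loss belongs to the 2,2,2-trichloroethyl group and not to every carbamate with a chain at this place. The recovery is only partial, however: methyl in place of hydrogen at the same carbon already gives a number 31.5 percentage points lower from compound 1 to compound 3 (beyond the scatter) even though methyl has only 1 heavy atom, so this position responds strongly to the smallest carbon addition as well as to the 4 heavy atoms of trichloromethyl. Among these three compounds, the number falls stepwise as the group on this carbon goes from hydrogen to methyl to trichloromethyl, and no compound goes against that order.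

Still open, going by these compounds, is where a longer chain such as propyl, or a 2,2,2-trifluoroethyl group, would fall in this order. Nothing measured alongside these numbers accounts for the order they form.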